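Swapping the sulfonyl aryl substituent toward a trifluoromethyl group

The source may report more compounds than this note shows. Statements on the series, on what has been measured and on what is new or still open speak of the compounds shown alone.

Of the compounds shown here, two have been tested in a functional assay on SK-MEL-28 cells (Homo sapiens) for cytotoxicity, read by MTT assay; a lower number here means a stronger inhibitor, a higher number a weaker inhibitor. Compound 1 `O=S(=O)(NCCCNc1nccc(-c2c(-c3cccc(F)c3)nc3sccn23)n1)c1cccc(F)c1` gives 8550 nM. Compound 2 `COc1ccc(S(=O)(=O)NCCCNc2nccc(-c3c(-c4cccc(F)c4)nc4sccn34)n2)cc1` gives 8980 nM. Among the measured compounds shown here, the one comparison available, a 1.1-fold higher number from compound 1 to compound 2 (0.02 log units; within the scatter), concerns only the aryl group on the sulfonyl sulfur and changed nothing that the assay can resolve. Compound 2 therefore carries the highest of the two numbers, but its gap to compound 1 is far inside the usual scatter, so the two stand level.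

Compound 3 `O=S(=O)(NCCCNc1nccc(-c2c(-c3cccc(F)c3)nc3sccn23)n1)c1ccc(C(F)(F)F)cc1` is the next variation on the same sulfonyl aryl group: trifluoromethyl in place of methoxy on an aromatic carbon. For the measured compounds named here, the single step that bears on this position, from compound 1 to compound 2, was flat, and nothing else in the data distinguishes one aryl substituent from another. The expectation for compound 3 in this assay is therefore a step of about a 1.1-fold lower number from compound 2 to compound 3 (0.02 log units; within the scatter), that is, none beyond the scatter. The estimate for compound 3 in this assay is 8500 nM, with a plausible range from 3500 nM to 20000 nM.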

Compound 3, half-maximal inhibitory concentration: 11700 nM
Compound 3: middle estimate off by 1.4-fold (0.14 log units), on the low side; low and high end bracket the measured number.
By their numbers in this assay, from the lowest: compounds 1, 2 and 3 (each within the scatter of the next).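

In this assay, trifluoromethyl in place of methoxy gives a 1.3-fold higher number from compound 2 to compound 3 (0.11 log units; within the scatter), and 4-(trifluoromethyl)phenyl in place of 3-fluorophenyl on the sulfonyl sulfur gives a 1.4-fold higher number from compound 1 to compound 3 (0.14 log units; within the scatter). Among the compounds shown here, the single earlier step compared only two aryl groups, whereas three now stand level, and the flat picture holds even when a trifluoromethyl group of 4 heavy atoms and 0 hydrogen-bond acceptors replaces a methoxy group of 2 heavy atoms and 1 hydrogen-bond acceptor on an aromatic carbon. No evidence on the cause of this result is available.

The compounds shown leave open whether the number in this assay would stay level with an amine or a carboxylic acid on this aromatic ring, or with a plain methyl group in place of the whole aryl group on the sulfonyl sulfur. All three also share the same linking chain and the same core, so they say nothing about how a longer chain or a change to the core would read in this assay.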